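Changing the Carbonyl Substituent on an Amide Nitrogen

This account rests on a few compounds, and the source may have more. Where it says the series, first, only, none or still open, it means among the compounds named here.

Compound 2 `Cc1ccc(C(=O)NC2=C(C#N)C(c3ccc(Cl)cc3Cl)C3=C(CCCC3=O)N2c2ccc(S(N)(=O)=O)cc2)cc1` carries a ((4-methylphenyl)carbonyl)amino group on the shared core. In a functional assay on Ehrlich cells (Mus musculus) for cytotoxicity, read by trypan blue exclusion, with a stated time of 2 h, tested at 100 ug/mL (a lower number here means a weaker effect, a higher number a stronger effect of the compound at the concentration tested), compound 2 gives 40%, the lowest of the two numbers at hand. Among the compounds with values here, its only measured neighbour is compound 1 `N#CC1=C(N)N(c2ccc(S(N)(=O)=O)cc2)C2=C(C(=O)CCC2)C1c1ccc(Cl)cc1Cl`, which in this assay gives 95%; the step of a number 55 percentage points lower from compound 1 to compound 2 (beyond the scatter) shows that placing a (4-methylphenyl)carbonyl in place of hydrogen on the amine nitrogen weakens the effect by a large amount. Compound 3 `N#CC1=C(NC(=O)/C=C/c2ccccc2)N(c2ccc(S(N)(=O)=O)cc2)C2=C(C(=O)CCC2)C1c1ccc(Cl)cc1Cl` keeps that amide but alters the group on its carbonyl carbon: 2-phenylethenyl in place of 4-methylphenyl on a carbonyl carbon. Within the data shown here, no measured step covers such an exchange of one carbonyl substituent for another; the one step available concerns adding the amide, not changing it. Since compound 2 and compound 3 are both amides of the same amine, the expected step of a number 5 percentage points higher from compound 2 to compound 3 (within the scatter) is small and likely within the scatter, though the lack of a comparable step leaves the estimate wide. Compound 3 is therefore expected to give 45% in this assay, with a range from 20% to 75%.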

Compound 3, a percentage reported as activity, at one concentration (the size of the read-out at that concentration, not a potency): 45%
Compound 3: the middle estimate sits on the measured number at the digits printed; the range from low to high includes it.
By their numbers in this assay, from the lowest: compounds 2 and 3 (each within the scatter of the next); then compound 1.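

In this assay, 2-phenylethenyl in place of 4-methylphenyl on a carbonyl carbon gives a step that lies within the scatter (a number 5 percentage points higher from compound 2 to compound 3 (within the scatter)), so the two groups cannot be told apart at this position, even though 2-phenylethenyl brings a double bond outside the aromatic ring. Compound 3 also stands far from the free amine of compound 1 (a number 50 percentage points lower from compound 1 to compound 3 (beyond the scatter)), which means the large fall on placing an amide at this nitrogen now holds for two different carbonyl substituents rather than one. No measurement at hand offers an explanation for either step.

Both carbonyl substituents shown carry a six-membered aromatic ring of carbon only, so it remains open whether a small methyl group, a longer saturated chain or a substituent ending in a carboxylic acid or an amine on the same carbonyl carbon would give a similar number. On these data alone, it is equally open whether the fall belongs to the amide itself or would also follow a simple alkyl group, such as ethyl, placed on the amine nitrogen.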